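The source may hold more compounds than are shown below. What is called first, only, known or untested is meant among the compounds shown, and "the series" means these compounds.

Working notes on the series. Three compounds sharing one core have numbers in a functional assay on 143B cells (Homo sapiens) for antiproliferative activity, read by MTT assay, with a stated time of 48 h; on this read-out higher numbers stand for weaker inhibition and lower numbers for stronger inhibition: compound 1 `O=C(Nc1cccc(/C=C/C(=O)c2nc3ccccc3[nH]2)c1)c1ccccc1` gives 8340 nM, compound 2 `O=C(/C=C/c1cccc(NC(=O)c2ccccc2Cl)c1)c1nc2ccccc2[nH]1` gives 3690 nM and compound 3 `Cc1ccc(C(=O)Nc2cccc(/C=C/C(=O)c3nc4ccccc4[nH]3)c2)cc1` gives 6560 nM. Compound 3 sits second highest of the three, close to compound 1 and further from compound 2, both gaps within the scatter. Compound 4 `O=C(/C=C/c1cccc(NS(=O)(=O)c2ccccc2Cl)c1)c1nc2ccccc2[nH]1` differs from compound 3 by (2-chlorophenyl)sulfonyl in place of (4-methylphenyl)carbonyl on a nitrogen on an aromatic ring. Among the compounds with values here, two measured steps bear on it: a 2.3-fold lower number from compound 1 to compound 2 (0.35 log units; beyond the scatter) and a 1.8-fold higher number from compound 2 to compound 3 (0.25 log units; within the scatter). Within the data shown here, the carbonyl-to-sulfonyl exchange has no precedent among the measured compounds. A modest downward step is expected, a 1.5-fold lower number from compound 3 to compound 4 (0.16 log units; within the scatter), because compound 2 with its 2-chlorophenyl gives 3690 nM. Compound 4 is estimated at 4500 nM, within 1500 nM to 14000 nM.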

Compound 4, half-maximal inhibitory concentration: 4790 nM
Compound 4: the middle estimate sits 1.1-fold (0.03 log units) below what was measured; the measured number falls inside the stated range.
By their numbers in this assay, from the lowest: compounds 2, 4, 3 and 1 (each within the scatter of the next, the first and the last beyond it).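

On the nitrogen on an aromatic ring, the sulfonyl link gives no step beyond the scatter in this assay. With 2-chlorophenyl kept, the exchange of carbonyl for sulfonyl reads (a 1.3-fold higher number from compound 2 to compound 4 (0.11 log units; within the scatter)), and the steps from the other two amides read (a 1.4-fold lower number from compound 3 to compound 4 (0.14 log units; within the scatter)) and (a 1.7-fold lower number from compound 1 to compound 4 (0.24 log units; within the scatter)). No measurement on hand accounts for these steps.

Still open, from the compounds shown here alone, is whether an amine or a carboxylic acid on the phenyl ring of the sulfonyl group, or a longer chain in place of that ring, would give a step beyond the scatter.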